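Aromatic hydroxy step carried from one core to another

A few compounds are considered here, and "the series" means these few. Any claim that something is new, unique, unknown or untested is made for them only; others in the source may bear on it.

Compound 1 `COc1ccc(C2CC(Nc3nc4ccc([N+](=O)[O-])cc4s3)=NN2C(C)=O)cc1` gives 145 umol/kg in a functional assay on the whole organism (Hindlimb, strain albino) with Mus musculus as the target, in the maximal electroshock model, with a stated time of 0.5 h; on this read-out higher numbers stand for an effect only at larger amounts of compound and lower numbers for an effect already at smaller amounts. Compound 2 `COc1ccc(C2CC(Nc3nc4ccc([N+](=O)[O-])cc4s3)=NN2C(C)=O)cc1O` differs from it by hydroxy in place of hydrogen on an aromatic carbon and gives 178 umol/kg in this assay; the step of a 1.2-fold higher number from compound 1 to compound 2 (0.09 log units; within the scatter). Compound 3 `O=C(/C=C/c1ccccc1)Nc1nc2ccc([N+](=O)[O-])cc2s1` gives 485 umol/kg in this assay, the highest number of the three measured; the difference between the core of compound 1 and the core of compound 3 is not broken down here.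

Compound 4 `O=C(/C=C/c1ccc(O)cc1)Nc1nc2ccc([N+](=O)[O-])cc2s1` has not been measured in this assay. It differs from compound 3 by hydroxy in place of hydrogen on an aromatic carbon. Among the compounds with values here, this is the same kind of change as the one from compound 1 to compound 2, not the same change: in compound 2 the hydroxy sits ortho to a methoxy group and meta to a large group, whereas in compound 4 it sits para to a large group, and the cores differ.

Within the data shown here, the step from compound 3 to compound 4 in this assay is expected to be small, a 1.1-fold higher number from compound 3 to compound 4 (0.04 log units; within the scatter), because the one measured instance of this kind of change, a 1.2-fold higher number from compound 1 to compound 2 (0.09 log units; within the scatter), stayed within the scatter. Compound 4 is estimated at 530 umol/kg in this assay, expected to lie between 250 umol/kg and 1100 umol/kg.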

Compound 4, dose for half-maximal effect: 382 umol/kg
Estimate against measurement, compound 4: 1.4-fold (0.14 log units) above; the measured number falls inside the stated range.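

In this assay the change gives a 1.3-fold lower number from compound 3 to compound 4 (0.10 log units; within the scatter) and so remains small on the core of compound 3 as well. Set beside the earlier step on the core of compound 1, this step does not differ from it: the same change on two cores in this assay, a 1.2-fold higher number (0.09 log units; within the scatter) from compound 1 to compound 2 and a 1.3-fold lower number (0.10 log units; within the scatter) from compound 3 to compound 4, 1.6-fold (0.19 log units) apart, within the scatter of two such steps

These two pairs support only a modest reading, that hydroxy in place of hydrogen on an aromatic carbon left the number within the scatter on both cores, and they give the change no direction and do not show that it would stay this small on any further core of the series.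

The compounds shown leave open whether a different group on the same aromatic carbon, such as an amine or a carboxylic acid in place of the hydroxy, would also stay within the scatter. On these data alone, it is equally open whether the hydroxy step would hold if the nitro group common to all four compounds gave way to an amine.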